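From phenyl to propyl: estimating compound 4

This account rests on a few compounds, and the source may have more. Where it says the series, first, only, none or still open, it means among the compounds named here.

Measured in a physicochemical assay for lipophilicity, measured as octanol-water partition; a lower number here means a more polar compound, a higher number a more lipophilic compound:
Compound 1 `CCCCCc1cn(C/C=C(/C)CC/C=C(\C)CCC=C(C)C)nn1`: 7.5
Compound 2 `CCCc1cn(C/C=C(/C)CCC=C(C)C)nn1`: 4.05
Compound 3 `CC(C)=CCC/C(C)=C/CC/C(C)=C\Cn1cc(-c2ccccc2)nn1`: 6.95

Compound 3 stands second highest of the three, below compound 1 and above compound 2. Compound 4 `CCCc1cn(C/C=C(/C)CC/C=C(\C)CCC=C(C)C)nn1` carries propyl in place of phenyl on an aromatic carbon. Among the measured compounds shown here, one measured step bears on this, a number 0.55 log units lower from compound 1 to compound 3 (beyond the scatter), a modest change with phenyl in place of pentyl. Compound 4 matches compound 1 except that propyl replaces pentyl, so a number somewhat below that of compound 1 seems likely. Compound 2 also has propyl and reads 4.05, but the rest of its structure differs too. The expected change is a number 0.45 log units lower from compound 3 to compound 4 (beyond the scatter), a modest one. The estimated value for compound 4 is 6.5, with an expected range of 6 to 7.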

Compound 4, partition coefficient: 6.5
Compound 4: the middle estimate sits on the measured number at the digits printed; measured number inside the range.
By their numbers in this assay, from the lowest: compound 2; then compound 4; then compound 3; then compound 1.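

In this assay, this aromatic carbon now has three groups to compare: propyl in place of phenyl gives a number 0.45 log units lower from compound 3 to compound 4 (beyond the scatter), and hydrogen in place of ethyl on the pentyl chain gives a number 1.00 log units lower from compound 1 to compound 4 (beyond the scatter). Both modest steps are smaller than the large one at the other end of the molecule, where 3-methylbut-2-en-1-yl in place of hydrogen gives a number 2.45 log units higher from compound 2 to compound 4 (beyond the scatter). Nothing given here explains these steps. Still open, going by these compounds, is how an amine or a carboxylic acid on this aromatic carbon would read, and whether phenyl or pentyl on the shorter chain of compound 2 would give similar steps.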